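The source may report more compounds than this note shows. Statements on the series, on what has been measured and on what is new or still open speak of the compounds shown alone.

In a functional assay on MGC-803 cells (Homo sapiens) for antiproliferative activity, read by CCK-8 assay, with a stated time of 72 h, tested at 2 uM (a higher number here means a stronger effect of the compound at the concentration tested, a lower number a weaker effect), three compounds that share one core have been measured. Compound 1 `Nc1ccccc1NC(=O)c1ccc(CSC(=S)N2CCN(c3ccc(Cl)cc3)CC2)cc1` gives 15%, compound 2 `Nc1ccccc1NC(=O)c1ccc(CSC(=S)N2CCN(c3ccccc3)CC2)cc1` gives 42.3%, and compound 3 `Nc1ccccc1NC(=O)c1ccc(CSC(=S)N2CCN(c3cccnc3)CC2)cc1` gives 27.6%. Compound 3 thus stands second highest of the three: the step of a number 12.6 percentage points higher from compound 1 to compound 3 (beyond the scatter) lies beyond the scatter, and so does the step of a number 14.7 percentage points lower from compound 2 to compound 3 (beyond the scatter).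

Compound 4 `COc1ccc(N2CCN(C(=S)SCc3ccc(C(=O)Nc4ccccc4N)cc3)CC2)cc1` has not yet been measured in this assay. It differs from compound 3 in a single place: 4-methoxyphenyl in place of pyridin-3-yl on an amine nitrogen in a ring. Two measured steps speak to this change. The step of a number 14.7 percentage points lower from compound 2 to compound 3 (beyond the scatter) shows that swapping phenyl for pyridin-3-yl went with a lower number, so returning to a carbon-only ring could raise it again. Against that, the step of a number 27.3 percentage points higher from compound 1 to compound 2 (beyond the scatter) shows that a chloro on the carbon-only ring went with a far lower number than plain phenyl, so a group on that ring can also go with a drop. Going by the values given here, no measured compound carries a methoxy group, so its own effect is unknown.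

Weighing both, compound 4 is expected to give about 30%, within roughly 12% to 50%. This estimate means a step of a number 2.4 percentage points higher from compound 3 to compound 4 (within the scatter), expected to stay within the scatter.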

Compound 4, a percentage reported as inhibition, at one concentration (the size of the read-out at that concentration, not a potency): 25.3%
Estimate against measurement, compound 4: 4.7 percentage points above; measured number inside the range.
By their numbers in this assay, from the lowest: compound 1; then compounds 4 and 3 (each within the scatter of the next); then compound 2.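

In this assay, the step of a number 17 percentage points lower from compound 2 to compound 4 (beyond the scatter) shows that the plain phenyl ring is not set apart from chloro alone: a methoxy group on that ring also goes with a lower number. The two groups do not count the same, though, as the step of a number 10.3 percentage points higher from compound 1 to compound 4 (beyond the scatter) separates methoxy from chloro at the same place on the ring, so the size of the drop depends on which group is attached. The step of a number 2.3 percentage points lower from compound 3 to compound 4 (within the scatter) leaves 4-methoxyphenyl and pyridin-3-yl level on the amine nitrogen in the ring, which means that among the four compounds only the unsubstituted phenyl of compound 2 stands clear of all the others.

The compounds shown leave open whether other groups on the phenyl ring, such as a fluoro, a methyl or an amine, would also fall short of compound 2, and how much of the difference between methoxy and chloro would carry over to them. Nothing available here accounts for any of these differences.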